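Urea series: removing one trifluoromethyl from compound 3

The source may hold more compounds than are shown below. What is called first, only, known or untested is meant among the compounds shown, and "the series" means these compounds.

Measured so far:
compound 1 `O=C(Nc1cccc(-n2cc(-c3ccncc3)c(-c3cc(O)cc(Cl)c3)n2)c1)Nc1ccc(Cl)c(C(F)(F)F)c1`, 53%
compound 2 `O=C(Nc1cccc(-n2cc(-c3ccncc3)c(-c3cc(O)cc(Cl)c3)n2)c1)Nc1ccc(Cl)c(Cl)c1`, 96%
compound 3 `COc1cc(Cl)cc(-c2nn(-c3cccc(NC(=O)Nc4cc(C(F)(F)F)cc(C(F)(F)F)c4)c3)cc2-c2ccncc2)c1`, 15%

In a functional assay on T47D cells (Homo sapiens) for inhibition, read by sulforhodamine B assay, with a stated time of 48 h, tested at 1 uM (on this read-out higher numbers stand for a weaker effect at the one concentration tested and lower numbers for a stronger effect), compound 3 gives the lowest of the three numbers, 15%; compound 1 gives 53% and compound 2 gives 96%, both beyond the scatter from it. Compound 4 `COc1cc(Cl)cc(-c2nn(-c3cccc(NC(=O)Nc4cccc(C(F)(F)F)c4)c3)cc2-c2ccncc2)c1` differs from compound 3 by hydrogen in place of trifluoromethyl on an aromatic carbon. For the measured compounds named here, no measured step removes a trifluoromethyl outright; the only step touching that group, a number 43 percentage points higher from compound 1 to compound 2 (beyond the scatter), replaces it and weakens the effect by a large amount. A weakening step is therefore expected, though its size is uncertain. For compound 4 the estimate is 45% (range 20% to 75%), an expected step of a number 30 percentage points higher from compound 3 to compound 4 (beyond the scatter).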

Compound 4, a percentage reported as activity, at one concentration (the size of the read-out at that concentration, not a potency): 58%
Compound 4: the middle estimate sits 13 percentage points below what was measured; the measured number falls inside the stated range.
By their numbers in this assay, from the lowest: compound 3; then compounds 1 and 4 (each within the scatter of the next); then compound 2.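

In this assay, for the compounds shown here, the step of a number 43 percentage points higher from compound 3 to compound 4 (beyond the scatter) is the first direct reading of a trifluoromethyl removed outright, with hydrogen left in its place. A large loss of effect follows even though compound 4 keeps one trifluoromethyl on the same ring, so the second group at this position is not dispensable in compound 3. No measurement at hand gives a cause for this loss.

The compounds shown leave open whether a nitrile or a methyl group at this position would hold the effect. On these data alone, whether the step carries over to a hydroxy core also stays open.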